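Swapping the Amine Substituent of Compound 2

The source may hold more compounds than are shown below. What is called first, only, known or untested is meant among the compounds shown, and "the series" means these compounds.

Compound 1 `Cc1ccc(C(=O)N2N=C(c3cc4ccccc4oc3=O)CC2c2ccccc2)cc1` and compound 2 `CCNCC(=O)N1N=C(c2cc3ccccc3oc2=O)CC1c1ccccc1` share a core and differ only at a carbonyl carbon. In a functional assay on MGC-803 cells (Homo sapiens) for cytotoxicity, read by MTT assay, with a stated time of 48 h (a lower number here means a stronger inhibitor, a higher number a weaker inhibitor), compound 1 gives 31300 nM and compound 2 gives 26600 nM; the step of a 1.2-fold lower number from compound 1 to compound 2 (0.07 log units; within the scatter) is within the scatter, so compound 2 sits alongside compound 1 rather than apart from it. Compound 3 `CC(C)(C)NCC(=O)N1N=C(c2cc3ccccc3oc2=O)CC1c1ccccc1` differs from compound 2 at the amine nitrogen: tert-butyl in place of ethyl on an amine nitrogen. Within the data shown here, no measured step touches this position, and the one recorded step altered a different group. No shift beyond the scatter is therefore expected, and a 1.1-fold lower number from compound 2 to compound 3 (0.03 log units; within the scatter) is the estimated step. Compound 3 is expected at 25000 nM, within 10000 nM to 60000 nM.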

Compound 3, half-maximal inhibitory concentration: 15400 nM
Compound 3: middle estimate off by 1.6-fold (0.21 log units), on the high side, within the range that was stated.
By their numbers in this assay, from the lowest: compounds 3, 2 and 1 (each within the scatter of the next, the first and the last beyond it).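

In this assay tert-butyl in place of ethyl on the amine nitrogen gives a 1.7-fold lower number from compound 2 to compound 3 (0.24 log units; within the scatter) and so does not separate the two groups at this position. The gap to the 4-methylphenyl compound does pass the scatter, modestly, with a 2.0-fold lower number from compound 1 to compound 3 (0.31 log units; beyond the scatter) as the step across the carbonyl carbon. Nothing available here explains these numbers. Still open, as far as these compounds go, is whether a cyclohexyl ring or a hydroxyethyl chain on that amine nitrogen would give a number clearly apart from those of compound 2 and compound 3.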